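The source may hold more compounds than are shown below. What is called first, only, known or untested is meant among the compounds shown, and "the series" means these compounds.

Working notes on the series.

Three members of the series have been measured in a functional assay on HCT-116 cells (Homo sapiens) for inhibition, read by sulforhodamine B assay, with a stated time of 48 h, tested at 50 uM; on this read-out higher numbers stand for more inhibition of growth at the one concentration tested and lower numbers for less inhibition of growth. Compound 1, `COc1ccccc1/C=C/C(=O)/C=C/c1ccc(OCc2cn(CCCOc3cc(=O)oc4ccccc34)nn2)c(OC)c1`, gives 53% in this assay. Compound 2, `COc1ccc(/C=C/C(=O)/C=C/c2ccc(OCc3cn(CCCCCOc4cc(=O)oc5ccccc45)nn3)c(OC)c2)cc1`, gives 35%, and compound 3, `COc1cc(/C=C/C(=O)/C=C/c2ccco2)ccc1OCc1cn(CCOc2cc(=O)oc3ccccc23)nn1`, gives 72%. Compound 1 therefore stands second highest of the three numbers: compound 2 lies below it by a gap beyond the usual scatter, and compound 3 lies above it by a gap that is likewise beyond the scatter. Within the data shown here, no pair of these measured compounds differs in only one place, so no single structural step among them can be read from the numbers; compounds 2 and 3 each differ from compound 1 both in the aryl group on the chain and in the length of the chain bearing the coumarinyl ether.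

The next compound to be measured is compound 4, `COc1cc(/C=C/C(=O)/C=C/c2cccs2)ccc1OCc1cn(CCCOc2cc(=O)oc3ccccc23)nn1`. It keeps the shared core of compound 1 and differs from it in one place: thiophen-2-yl in place of 2-methoxyphenyl on a double-bonded chain carbon bound to a double-bonded chain carbon. Among the measured compounds shown here, with no one-place step available among the measured compounds, the size of this step is not known from the data. A step of modest size in the upward direction is expected, and it may well fall within the scatter: the expected change from compound 1 to compound 4 in this assay is a number 7 percentage points higher from compound 1 to compound 4 (within the scatter). Compound 4 is estimated to give 60% in this assay, with a range from 42% to 78%.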

Compound 4, percent growth inhibition at one concentration: 58%
For compound 4 the middle estimate is 2 percentage points above the measured one, within the range that was stated.
By their numbers in this assay, from the lowest: compound 2; then compounds 1 and 4 (each within the scatter of the next); then compound 3.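

Among these compounds, the change from 2-methoxyphenyl to thiophen-2-yl on a double-bonded chain carbon bound to a double-bonded chain carbon gives the first step that can be read at a single place, and in this assay it stands as a number 5 percentage points higher from compound 1 to compound 4 (within the scatter). At this place, in this read-out and at the one concentration tested, a six-membered aromatic ring of carbon only with 8 heavy atoms can thus be exchanged for a five-membered aromatic ring with 1 hetero atom and 5 heavy atoms with no change that stands clear of the scatter. No measurement at hand bears on why these two groups give values within the scatter of each other.

From the compounds shown here alone, it remains open how this place responds to groups of another kind, such as pyridin-2-yl, 4-(dimethylamino)phenyl or an aryl group carrying a carboxylic acid. Going by these compounds, it also remains open whether thiophen-2-yl gives a similar value when paired with a longer chain, and the separate contributions of aryl group and chain length to the values of compound 2 and compound 3 cannot be read.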